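The source may hold more compounds than are shown below. What is called first, only, known or untested is meant among the compounds shown, and "the series" means these compounds.

Compound 1 `COc1cc(C(=O)/C=C/c2ccc(O)cc2)cc(OC)c1OC` gives 16000 nM in a functional assay on HepG2 cells (Homo sapiens) for inhibition, read by MTT assay, with a stated time of 48 h; on this read-out lower numbers stand for stronger inhibition and higher numbers for weaker inhibition. Compound 2 `COc1cc(/C=C/C(=O)c2cc(OC)c(OC)c(OC)c2)ccc1O` returns only a limit of this assay, > 100000 nM. Compound 3 `COc1cc(C(=O)/C=C/c2cc(O)ccc2O)cc(OC)c1OC` likewise returns only a limit, > 100000 nM. Compound 3 therefore stands at the limit of > 100000 nM in this assay, at which 2 of the 3 values shown sit, with no number of its own. Both measured steps start from compound 1: an at least 6.2-fold higher number from compound 1 to compound 2 (0.79 log units; beyond the scatter), and an at least 6.2-fold higher number from compound 1 to compound 3 (0.79 log units; beyond the scatter). Compound 4 `COc1cc(C(=O)/C=C/c2ccc(O)c(O)c2)cc(OC)c1OC` differs from compound 3 by 3,4-dihydroxyphenyl in place of 2,5-dihydroxyphenyl on a double-bonded chain carbon bound to a double-bonded chain carbon. Within the data shown here, only the step from compound 1 to compound 3 concerns the hydroxyl pattern; compound 4 keeps the hydroxyl arrangement of compound 1 and adds one more, so a step back toward compound 1 is expected, though not a full return. The expected step is an at least 3.3-fold lower number from compound 3 to compound 4 (0.52 log units; beyond the scatter). Compound 4 is estimated at 30000 nM, within 8000 nM to 100000 nM.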

Compound 4, half-maximal inhibitory concentration: 14900 nM
Estimate against measurement, compound 4: 2.0-fold (0.30 log units) above; low and high end bracket the measured number.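

Compound 3 and compound 4 hold the same atoms, so the arrangement of the hydroxy groups alone accounts for an at least 6.7-fold lower number from compound 3 to compound 4 (0.82 log units; beyond the scatter). An added hydroxy group gives a 1.1-fold lower number from compound 1 to compound 4 (0.03 log units; within the scatter), whereas hydrogen in place of methyl on an oxygen on an aromatic ring gives an at least 6.7-fold lower number from compound 2 to compound 4 (0.82 log units; beyond the scatter), so the added oxygen is accepted while its methyl goes with the loss. Compound 2 and compound 3 each give a limit, not a number: the limit of > 100000 nM in this assay, at which 2 of the 4 values shown sit.

Going by these compounds, the full size of both steps from those limits remains open. Also open, on these data alone, is whether an amine or a carboxylic acid could stand in place of the hydroxy group of compound 1.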